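Series notes: chloro added on the benzyl ring

The source may hold more compounds than are shown below. What is called first, only, known or untested is meant among the compounds shown, and "the series" means these compounds.

Of the compounds shown here, three sharing one core have been measured in a functional assay on GBM2 cells (Homo sapiens) for antiproliferative activity, read by WST assay, with a stated time of 72 h; on this read-out higher numbers stand for weaker inhibition and lower numbers for stronger inhibition. Compound 1 `O=C(Nc1ccc(Cl)c(Cl)c1)Nc1cc2ncncc2cc1OCc1cccc(F)c1` gives 1500 nM. Compound 2 `O=C(Nc1cccc(Cl)c1)Nc1cc2ncncc2cc1OCc1ccccc1` gives 4100 nM. Compound 3 `O=C(Nc1ccccc1F)Nc1cc2ncncc2cc1OCc1cccc(Cl)c1` gives 4400 nM. Among these three numbers compound 2 stands second highest: its nearest neighbour is compound 3, within the scatter, while compound 1 lies furthest from it, beyond the scatter, with the lower number. Among the measured compounds shown here, no two of the measured compounds differ in only one place, so there is no measured step with which to calibrate the change now in hand.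

Compound 4 `O=C(Nc1cccc(Cl)c1)Nc1cc2ncncc2cc1OCc1ccccc1Cl` is not yet measured. It differs from compound 2 by chloro in place of hydrogen on an aromatic carbon, that is, benzyl to 2-chlorobenzyl. For the measured compounds named here, nothing among the measured compounds tests this change on its own, so the expectation rests on the general spread of the three numbers. For compound 4 the expected step is a 1.3-fold lower number from compound 2 to compound 4 (0.11 log units; within the scatter), a change not beyond the scatter. The estimate for compound 4 in this assay is 3200 nM, with a range from 1300 nM to 8000 nM.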

Compound 4, half-maximal inhibitory concentration: 2100 nM
Compound 4: the middle estimate sits 1.5-fold (0.18 log units) above what was measured; measured number inside the range.
By their numbers in this assay, from the lowest: compounds 1, 4, 2 and 3 (each within the scatter of the next, the first and the last beyond it).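

In this assay, among the compounds shown here, the first one-place step, benzyl to 2-chlorobenzyl, gives a 2.0-fold lower number from compound 2 to compound 4 (0.29 log units; within the scatter). This place, on an aromatic carbon ortho to a large group, therefore accepts chloro in place of hydrogen with no change beyond the scatter, a reading that rests on this single pair. No measurement on hand bears on the result, so nothing can be said about what lies behind it.

Open, from the compounds shown here alone, is whether a methoxy group, an amine or a carboxylic acid at this same place would move the number beyond the scatter. Also open, going by these compounds, is whether chloro here gives a similar step when the rest of the molecule differs, since compounds 1 and 3 differ from compound 4 in more than one place and offer no direct comparison.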